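This account rests on a few compounds, and the source may have more. Where it says the series, first, only, none or still open, it means among the compounds named here.

Working notes on the series.

Compound 1 `C=C1[C@@H](OC(C)=O)C[C@@H]2[C@](C)(COC=O)[C@H](OC(C)=O)CC[C@@]2(C)[C@@H]1C/C=C1/C(=O)OC[C@H]1OC(C)=O` and compound 2 `C=C1[C@@H](OC(C)=O)C[C@@H]2[C@](C)(CO[Si](C)(C)C(C)(C)C)[C@H](OC(C)=O)CC[C@@]2(C)[C@@H]1C/C=C1/C(=O)OC[C@H]1OC(C)=O` share a core and differ in one place only: a group of 7 heavy atoms (6 carbon, 1 silicon; no ring) in place of a group of 2 heavy atoms (1 carbon, 1 oxygen; no ring), on an oxygen on a saturated carbon. In a functional assay on HT-29 cells (Homo sapiens) for cytotoxicity, read by sulforhodamine B assay (on this read-out higher numbers stand for weaker inhibition and lower numbers for stronger inhibition), compound 1 gives 8290 nM, and compound 2 gives 4940 nM. The resulting step, a 1.7-fold lower number from compound 1 to compound 2 (0.22 log units; within the scatter), is small enough that the two numbers cannot be told apart with confidence.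

Compound 3 `C=C1[C@@H](OC(C)=O)C[C@@H]2[C@](C)(COC=O)[C@H](OC(C)=O)CC[C@@]2(C)[C@@H]1C[C@@H](Nc1ccccc1)C1=CCOC1=O` carries a different core; the difference between its core and the core of compound 1 is not broken down here. In this assay compound 3 gives 28800 nM, the highest of the three measured numbers, and its steps to compound 1 and to compound 2 both lie beyond the scatter.

Compound 4 `C=C1[C@@H](OC(C)=O)C[C@@H]2[C@](C)(CO[Si](C)(C)C(C)(C)C)[C@H](OC(C)=O)CC[C@@]2(C)[C@@H]1C[C@@H](Nc1ccccc1)C1=CCOC1=O` is the counterpart of compound 3 with the same change that leads from compound 1 to compound 2: a group of 7 heavy atoms (6 carbon, 1 silicon; no ring) in place of a group of 2 heavy atoms (1 carbon, 1 oxygen; no ring), on an oxygen on a saturated carbon. The place is described in identical words for both pairs, so this is the same change on a second core, occurring twice among the four compounds.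

For compound 4 in this assay the expected step is a 1.4-fold lower number from compound 3 to compound 4 (0.16 log units; within the scatter), beside the measured step from compound 1 to compound 2 that stayed within the scatter; the expectation rests on that one pair and on the value of compound 3, 28800 nM, with no other instance of the change on this core available. Compound 4 is therefore estimated at 20000 nM, with a range from 8000 nM to 50000 nM.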

Compound 4, half-maximal inhibitory concentration: 4050 nM
Compound 4: middle estimate off by 4.9-fold (0.69 log units), on the high side; measured number below the stated range.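

On the core of compound 3, putting the silicon-bearing group of 7 heavy atoms in place of formyl, on an oxygen on a saturated carbon, gives in this assay a 7.1-fold lower number from compound 3 to compound 4 (0.85 log units; beyond the scatter). The size of this change therefore does not carry from one core to the other in this series, since the two steps differ by more than the scatter allows: the same change on two cores in this assay, a 1.7-fold lower number (0.22 log units; within the scatter) from compound 1 to compound 2 and a 7.1-fold lower number (0.85 log units; beyond the scatter) from compound 3 to compound 4, 4.2-fold (0.63 log units) apart, beyond the scatter of two such steps. This rests on two pairs only: it shows that a step read on one core is a poor guide to the step on the other, but it does not show which part of the cores accounts for the gap, and it cannot establish a shared direction, since only the second step lies beyond the scatter.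

The compounds shown leave open what a hydrogen or a benzyl group on that oxygen would give on either core, and so whether the larger step belongs to this silicon-bearing group in particular or to any replacement of formyl. They also leave open whether the step would stay as large on the core of compound 3 with a cyclohexylamine in place of the aniline nitrogen substituent.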